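The source may report more compounds than this note shows. Statements on the series, on what has been measured and on what is new or still open speak of the compounds shown alone.

Compound 1 `O=C(Nc1ccccn1)c1cccc(Nc2ncc(F)c(Nc3ccc(F)cc3)n2)c1` gives 15300 nM in a functional assay on A549 cells (Homo sapiens) for antiproliferative activity, read by sulforhodamine B assay, with a stated time of 3 days (on this read-out lower numbers stand for stronger inhibition of growth and higher numbers for weaker inhibition of growth), the highest of the three numbers shown. Compound 2 `O=C(c1cccc(Nc2ncc(F)c(Nc3ccc(F)cc3)n2)c1)N1CCCCC1` gives 13200 nM, and the step of a 1.2-fold lower number from compound 1 to compound 2 (0.06 log units; within the scatter) alters only the group on the carbonyl carbon. Compound 3 `O=C(Nc1cccc(Nc2ncc(F)c(Nc3ccc(F)cc3)n2)c1)c1cccc([N+](=O)[O-])c1`, which reverses the amide and carries a nitrophenyl group, gives 7250 nM. Compound 4 `COCC(=O)Nc1cccc(Nc2ncc(F)c(Nc3ccc(F)cc3)n2)c1` arises from compound 1 by ((methoxymethyl)carbonyl)amino in place of (pyridin-2-yl)carbamoyl on an aromatic carbon. Among the compounds with values here, no measured step covers this exact change; the step from compound 1 to compound 2 stayed within the scatter, and compound 3 shows a lower number with a reversed amide. A small downward step a 1.5-fold lower number from compound 1 to compound 4 (0.18 log units; within the scatter) is therefore expected for compound 4. Compound 4 is estimated at 10000 nM, within a range from 3000 nM to 30000 nM.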

Compound 4, concentration for 50% growth inhibition: 2050 nM
Compound 4: the middle estimate sits 4.9-fold (0.69 log units) above what was measured; measured number outside the range, below it.
By their numbers in this assay, from the lowest: compound 4; then compounds 3, 2 and 1 (each within the scatter of the next, the first and the last beyond it).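

In this assay, this position on the carbon-only aromatic ring can move the number beyond the scatter: ((methoxymethyl)carbonyl)amino gives a 7.5-fold lower number from compound 1 to compound 4 (0.87 log units; beyond the scatter) and a 6.4-fold lower number from compound 2 to compound 4 (0.81 log units; beyond the scatter), although exchanging the groups on the carbonyl carbon between compound 1 and compound 2 did not. With the reversed amide kept, methoxymethyl in place of 3-nitrophenyl gives a 3.5-fold lower number from compound 3 to compound 4 (0.55 log units; beyond the scatter), so the reversed amide alone does not set the number. No measurement shown here explains this change.

On these data alone, it remains open whether the ether oxygen matters, as a plain acetyl group or a longer alkoxyalkyl chain would show. A terminal amine on the chain is also untested among the compounds shown.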